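Replacing a Formylphenyl Arm with Naphthalen-1-yl

The compounds below may be only part of what the source reports. "The series", "measured", "known", "first", "only" and "open" are said of these compounds alone.

Measured so far:
Compound 1 `COc1ccc(-c2cn3ccnc3c(-c3ccc4ncn(C5CCCCC5)c4c3)n2)cc1`: 91.7%
Compound 2 `O=Cc1ccc(-c2cn3ccnc3c(-c3ccc4ncn(C5CCCCC5)c4c3)n2)cc1`: 47.5%

In a functional assay on SR cells (Homo sapiens) for inhibition, read by sulforhodamine B assay, with a stated time of 48 h, tested at 10 uM (on this read-out lower numbers stand for less inhibition and higher numbers for more inhibition at the one concentration tested (going by the name of the read-out)), compound 2 stands lowest of the two numbers shown; its nearest neighbour is compound 1, well apart from it. Going by the values given here, the only measured step is a number 44.2 percentage points lower from compound 1 to compound 2 (beyond the scatter), a change of group on the same aromatic carbon. Compound 3 `c1ccc2c(-c3cn4ccnc4c(-c4ccc5ncn(C6CCCCC6)c5c4)n3)cccc2c1` carries a different group again at that place: naphthalen-1-yl in place of 4-formylphenyl on an aromatic carbon. Among the compounds with values here, no measured step covers a naphthalen-1-yl, so the single step bears only indirectly, by showing that the read-out moves strongly when this group is exchanged. Given that compound 1 reaches 91.7% with a group lacking the formyl, a rise is expected for compound 3, of roughly a number 24.5 percentage points higher from compound 2 to compound 3 (beyond the scatter), with wide uncertainty. Compound 3 is therefore estimated at 72%, between 40% and 95%.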

Compound 3, a percentage reported as inhibition, at one concentration (the size of the read-out at that concentration, not a potency): 6.92%
Compound 3: the middle estimate sits 65.1 percentage points above what was measured, outside the stated range (below it).
By their numbers in this assay, from the lowest: compound 3; then compound 2; then compound 1.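

In this assay, taking naphthalen-1-yl for 4-formylphenyl gives a number 40.6 percentage points lower from compound 2 to compound 3 (beyond the scatter), and taking it for 4-methoxyphenyl gives a number 84.8 percentage points lower from compound 1 to compound 3 (beyond the scatter). Going by these compounds alone, the earlier pair compared only two substituted phenyl groups, whereas this result shows that a group made of two six-membered aromatic rings of carbon only gives the lowest number of the three, so having an aromatic group at this place does not by itself keep the inhibition high. No supporting measurement bears on what lies behind this drop.

The compounds shown leave open how a phenyl ring carrying an amine or a carboxylic acid would read here. They also leave open whether naphthalen-2-yl, attached through a different ring carbon, would fall as low as naphthalen-1-yl.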